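Ring Size at the Chain End: Expecting Compound 4

This account rests on a few compounds, and the source may have more. Where it says the series, first, only, none or still open, it means among the compounds named here.

Compound 1 `COc1cc2c(Oc3ccc(NC(=O)c4nnn(-c5ccccc5C)c4C)cc3F)ccnc2cc1OCCCN1CCCC1` and compound 3 `COc1cc2c(Oc3ccc(NC(=O)c4nnn(-c5ccccc5C)c4C)cc3F)ccnc2cc1OCCCN1CCCCC1` share one core and differ in a single place: piperidin-1-yl in place of pyrrolidin-1-yl on a saturated chain carbon, three bonds along the chain from an oxygen on an aromatic ring. In a functional assay on NCI-H460 cells (Homo sapiens) for cytotoxicity, read by MTT assay, with a stated time of 72 h (a lower number here means a stronger inhibitor, a higher number a weaker inhibitor), compound 1 gives 720 nM and compound 3 gives 780 nM. The step reads a 1.1-fold higher number from compound 1 to compound 3 (0.03 log units; within the scatter). Compound 2 `COc1cc2c(Oc3ccc(NC(=O)c4nnn(-c5ccc(F)cc5)c4C(F)(F)F)cc3F)ccnc2cc1OCCCN1CCCC1` carries a different core; how its core differs from that of compound 1 is not broken down here. In this assay compound 2 gives 150 nM, the lowest of the three numbers. Compound 4 `COc1cc2c(Oc3ccc(NC(=O)c4nnn(-c5ccc(F)cc5)c4C(F)(F)F)cc3F)ccnc2cc1OCCCN1CCCCC1` relates to compound 2 as compound 3 relates to compound 1: piperidin-1-yl in place of pyrrolidin-1-yl on a saturated chain carbon, three bonds along the chain from an oxygen on an aromatic ring. The step in this assay is expected to be small, a 1.1-fold higher number from compound 2 to compound 4 (0.04 log units; within the scatter), because the earlier step measured a 1.1-fold higher number from compound 1 to compound 3 (0.03 log units; within the scatter). For compound 4 the estimate in this assay is 165 nM, with a likely range from 80 nM to 340 nM.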

Compound 4, half-maximal inhibitory concentration: 190 nM
For compound 4 the middle estimate is 1.2-fold (0.06 log units) below the measured one; the range from low to high includes it.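

The swap of pyrrolidin-1-yl for piperidin-1-yl gives a 1.3-fold higher number from compound 2 to compound 4 (0.10 log units; within the scatter) in this assay and so produces no change that stands clear of the scatter. The swap behaves alike on the two cores: the same change on two cores in this assay, a 1.1-fold higher number (0.03 log units; within the scatter) from compound 1 to compound 3 and a 1.3-fold higher number (0.10 log units; within the scatter) from compound 2 to compound 4, 1.2-fold (0.07 log units) apart, within the scatter of two such steps. This shows that the swap carried over between these two cores, but two pairs cannot show that it would stay this small on every core in the series.

The compounds shown leave open what happens with other groups at the chain end, such as morpholine or dimethylamine. They also leave open whether a longer chain than the propyl chain in 3-(piperidin-1-yl)propyl would keep the numbers this close.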